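From Oxan-4-yl to Benzyl: What to Expect for Compound 4

This account rests on a few compounds, and the source may have more. Where it says the series, first, only, none or still open, it means among the compounds named here.

Three compounds have been measured in an in vitro functional assay on cells for agonist activity at Bombesin receptor subtype-3 (Homo sapiens), read by luminescence and calcium flux; on this read-out lower numbers stand for an effect already at smaller amounts and higher numbers for an effect only at larger amounts of compound:
Compound 1 `CCCCc1cnc(C(C)Cc2ccc(-c3ccccc3C(=O)O)cc2)[nH]1` gives 2760 nM.
Compound 2 `O=C(O)c1ccccc1-c1ccc(CCc2ncc(CC3CCOCC3)[nH]2)cc1` gives 338 nM.
Compound 3 `CCC(C)(C)Cc1c[nH]c(CCc2ccc(-c3ccccc3C(=O)O)cc2)n1` gives 25 nM.

Compound 2 stands in the middle of the three. Its number is far below that of compound 1 and far above that of compound 3, and both gaps lie beyond the usual scatter. Compound 4 `O=C(O)c1ccccc1-c1ccc(CCc2ncc(CCc3ccccc3)[nH]2)cc1` has not been measured yet. It differs from compound 2 in a single spot: benzyl in place of oxan-4-yl on a saturated chain carbon bound to an aromatic carbon. Among the compounds with values here, no measured pair shows this exact exchange, so the size of the step is open. Within the data shown here, on the numbers so far, the carbon-only side group of compound 3 goes with the lowest value, which is the only hint available. A modest lowering is expected, a 2.3-fold lower number from compound 2 to compound 4 (0.35 log units; beyond the scatter). Compound 4 is therefore estimated at 150 nM, within a range from 40 nM to 600 nM.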

Compound 4, half-maximal effective concentration: 1320 nM
Compound 4: middle estimate off by 8.8-fold (0.94 log units), on the low side, and the stated range ends below it.
By their numbers in this assay, from the lowest: compound 3; then compound 2; then compound 4; then compound 1.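

Putting benzyl in place of oxan-4-yl on this saturated chain carbon gives a 3.9-fold higher number from compound 2 to compound 4 (0.59 log units; beyond the scatter). The position therefore responds to the ring it carries, and a carbon-only side group does not by itself bring a lower number here. No measurement shown explains this step.

As far as these compounds go, this single exchange changes the ring type, the ring oxygen and the heavy-atom count together, so the effect of each remains open. A cyclohexyl group in place of oxan-4-yl would keep a saturated ring while removing only the oxygen.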